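The source may report more compounds than this note shows. Statements on the series, on what has been measured and on what is new or still open speak of the compounds shown alone.

The measured compounds:
Compound 1, `C=Cc1cccc(C(=O)NCN2CCC(c3cccc[n+]3[O-])CC2)c1`: 63%
Compound 2, `Cc1cccc(C(=O)NCN2CCC(c3cccc[n+]3[O-])CC2)c1`: 77%
Compound 3, `N#Cc1cccc(C(=O)NCN2CCC(c3cccc[n+]3[O-])CC2)c1`: 69%

In a functional assay on HEK293 cells for agonist activity at D(4) dopamine receptor (Homo sapiens), read by FLIPR (on this read-out higher numbers stand for larger maximal responses and lower numbers for smaller maximal responses), compound 3 gives 69%, the second highest of the three numbers. The nearest neighbour is compound 1, and the step of a number 6 percentage points higher from compound 1 to compound 3 (within the scatter) stays within the scatter. The furthest is compound 2, and the step of a number 8 percentage points lower from compound 2 to compound 3 (within the scatter) also stays within the scatter. Going by the values given here, the only step beyond the scatter among the three is a number 14 percentage points higher from compound 1 to compound 2 (beyond the scatter), which does not touch compound 3 at all.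

Compound 4, `CCOc1cccc(C(=O)NCN2CCC(c3cccc[n+]3[O-])CC2)c1`, is the next compound to be measured. It differs from compound 3 in one place: ethoxy in place of cyano on an aromatic carbon.

Among the compounds with values here, no measured step exchanges cyano for ethoxy, so nothing directly mirrors this change. The two steps that do bear on the same aromatic carbon, a number 6 percentage points higher from compound 1 to compound 3 (within the scatter) and a number 8 percentage points lower from compound 2 to compound 3 (within the scatter), are both within the scatter, and the three measured values sit close together. On that basis compound 4 is expected to show no step beyond the scatter in this assay, a number 1 percentage points higher from compound 3 to compound 4 (within the scatter). The estimate for compound 4 in this assay is 70%, expected to lie between 55% and 85%.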

Compound 4, largest response reached (reported as efficacy), in percent of the reference or control that the assay uses: 54%
Beside the measured number, compound 4's estimate is 16 percentage points above it; the whole stated range lies above it.
By their numbers in this assay, from the lowest: compounds 4, 1, 3 and 2 (each within the scatter of the next, the first and the last beyond it).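

In this assay, going by these compounds alone, no step touching compound 3 had yet passed the scatter, but ethoxy on this aromatic carbon, meta to a large group, gives a number 15 percentage points lower from compound 3 to compound 4 (beyond the scatter) and, against the methyl group, a number 23 percentage points lower from compound 2 to compound 4 (beyond the scatter) as well. The position is therefore not indifferent to the group it carries, although the ethoxy and vinyl groups cannot be told apart, with a number 9 percentage points lower from compound 1 to compound 4 (within the scatter) on the same read-out. Nothing measured here says why the maximal response shifts when ethoxy enters.

The compounds shown leave open whether the lower response goes with the oxygen of the ethoxy group or with the length of its chain, and a methoxy or a propoxy group on this aromatic carbon would bear on that question. They also leave open how an amine or a carboxylic acid would read at this place, and whether the ethoxy step would hold on another carbon of the ring.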